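Selenium and Amino Substituents on a Fused Bicyclic Core

A few compounds are considered here, and "the series" means these few. Any claim that something is new, unique, unknown or untested is made for them only; others in the source may bear on it.

Compound 1 `C[Se]c1nc(N)c2ccccc2n1` was tested in a functional assay on HT-29 cells (Homo sapiens) for cytotoxicity, read by MTT assay, with a stated time of 72 h (a lower number here means a stronger inhibitor of growth, a higher number a weaker inhibitor of growth), and gave 74800 nM. Compound 3 `CSc1nc(NCCCc2ccccc2)c2ccccc2n1` gave 89600 nM in this assay. For compound 2 `C[Se]c1nc([Se]C)c2cccnc2n1` the outcome in this assay is "not determined" (no result reported), so compound 2 stands without a number beside the two measured values. Compound 4 `C[Se]c1nc(N)c2cccnc2n1` differs from compound 2 by one nitrogen atom in place of a group of 2 heavy atoms (1 carbon, 1 selenium; no ring), on an aromatic carbon, on an aromatic carbon. With no measured step between any two of these compounds, the size and direction of the change from compound 2 to compound 4 in this assay cannot be taken from the data, and no direction is expected to be claimed. Compound 4 is expected to give about 70000 nM in this assay, within a range from 25000 nM to 200000 nM, because compound 1 with the same amino group gives 74800 nM.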

Compound 4, concentration for total growth inhibition: 77300 nM
Estimate against measurement, compound 4: 1.1-fold (0.04 log units) below; the measured number falls inside the stated range.
By their numbers in this assay, from the lowest: compounds 1, 4 and 3 (each within the scatter of the next).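

No new step can be read from the result for compound 4 set against compound 2. Nothing shown here offers evidence bearing on this result. The compounds shown leave open how exchanging the amino group of compound 4 changes growth inhibition.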